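Selenium-bearing coumarins: from selenocarbamate to selenourea

The compounds below may be only part of what the source reports. "The series", "measured", "known", "first", "only" and "open" are said of these compounds alone.

Measured compounds:
compound 1 `Cc1cc(=O)oc2cc(N=C=[Se])ccc12` — 3600 nM
compound 2 `COC(=[Se])Nc1ccc2c(C)cc(=O)oc2c1` — > 100000 nM
compound 3 `CCCOC(=[Se])Nc1ccc2c(C)cc(=O)oc2c1` — 37000 nM

In a functional assay on A549 cells (Homo sapiens) for inhibition, read by sulforhodamine B assay, with a stated time of 48 h (a lower number here means a stronger inhibitor of growth, a higher number a weaker inhibitor of growth), compound 1 gives 3600 nM. Compound 2 gives only a limit of the assay, > 100000 nM. Compound 3 gives 37000 nM and so stands highest among the two numbers shown, with compound 1 as its nearest neighbour. The step of an at least 27-fold higher number from compound 1 to compound 2 (1.44 log units; beyond the scatter) is large; the step of an at least 2.7-fold lower number from compound 2 to compound 3 (0.43 log units; beyond the scatter) is at least modest, and is the one that bears on the change now considered, since it too lengthens the group on the chain carbon. Compound 4 `Cc1cc(=O)oc2cc(NC(=[Se])Nc3ccccc3)ccc12` differs from compound 3 in one place: anilino in place of propoxy on a saturated chain carbon bound to a nitrogen on an aromatic ring. The entering group is larger than the leaving propoxy and carries a hydrogen-bond donor that propoxy lacks. Given the direction of the step from compound 2 to compound 3, a decrease in the number in this assay for compound 4 is expected, most likely modest. The expected step is a 3.1-fold lower number from compound 3 to compound 4 (0.49 log units; beyond the scatter). Compound 4 is therefore estimated at 12000 nM, within the range 3000 nM to 50000 nM.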

Compound 4, concentration for 50% growth inhibition: 28000 nM
For compound 4 the middle estimate is 2.3-fold (0.37 log units) below the measured one, and the stated range covers the measured number.
By their numbers in this assay, from the lowest: compound 1; then compounds 4 and 3 (each within the scatter of the next). At a limit, above all of these: compound 2.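

In this assay the exchange on a saturated chain carbon bound to a nitrogen on an aromatic ring gives a 1.3-fold lower number from compound 3 to compound 4 (0.12 log units; within the scatter) for anilino in place of propoxy, so this position tolerates an aromatic ring and a hydrogen-bond donor without a change that can be read. Anilino in place of methoxy gives an at least 3.5-fold lower number from compound 2 to compound 4 (0.55 log units; beyond the scatter) and so stands on the same side of that step as propoxy, which the earlier compounds could show only for an ether chain. Compound 2 is held only at a limit of the assay: the limit of > 100000 nM in this assay, at which 1 of the 4 values shown sits.

The compounds shown leave open whether a longer chain on the oxygen, or a methylamino group in place of anilino, would keep this level. They also leave open whether a chlorine or a methoxy group on the anilino ring would move the number beyond the scatter.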